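Working notes on a small cytotoxicity series

A few compounds are considered here, and "the series" means these few. Any claim that something is new, unique, unknown or untested is made for them only; others in the source may bear on it.

Measured in a functional assay on HT-29 cells (Homo sapiens) for cytotoxicity, read by MTT assay, with a stated time of 72 h; a lower number here means a stronger inhibitor of growth, a higher number a weaker inhibitor of growth:
compound 1, `COc1ccc(CNc2nc([Se]C)nc3ccccc23)cc1`: 73600 nM
compound 2, `COc1ccc(CNc2nc([SeH])nc3ccccc23)cc1`: 71600 nM
compound 3, `CCCCCSc1nc(NCc2ccc([Se]C)cc2)c2ccccc2n1`: 14400 nM

Compound 2 holds the second highest of the three numbers. Within the data shown here, its nearest neighbour is compound 1, and the only single-point step in the set, a 1.0-fold lower number from compound 1 to compound 2 (0.01 log units; within the scatter), concerns hydrogen in place of methyl on a selenium. Among the measured compounds shown here, compound 3 gives the lowest number of the three, and the gap from compound 2 lies beyond the scatter, but compound 3 differs from compound 2 in more than one place, so no single step is defined between them.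

Pending is compound 4, `[SeH]c1nc(NCc2ccccc2)c2ccccc2n1`. Relative to compound 2 the change is hydrogen in place of methoxy on an aromatic carbon, on an aromatic carbon of a six-membered aromatic ring of carbon only, para to a large group. For the measured compounds named here, no measured step touches this position: the one measured step concerns the selenium substituent and is within the scatter. There is therefore no basis for a directional expectation, and the step of a 1.0-fold lower number from compound 2 to compound 4 (0.01 log units; within the scatter) is expected to stay within the scatter. Compound 4 is estimated to give 70000 nM, with a range from 25000 nM to 200000 nM.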

Compound 4, concentration for 50% growth inhibition: 62200 nM
The estimate for compound 4 lay 1.1-fold (0.05 log units) above the measured number, within the range that was stated.
By their numbers in this assay, from the lowest: compound 3; then compounds 4, 2 and 1 (each within the scatter of the next).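

In this assay, among these compounds, hydrogen in place of methoxy on an aromatic carbon gives a 1.2-fold lower number from compound 2 to compound 4 (0.06 log units; within the scatter) and so provides the first measured step at this position, on a six-membered aromatic ring of carbon only and para to a large group, where the earlier step concerned only the substituent on the selenium. The step does not separate the two compounds, so with a hydrogen on the selenium, the methoxy, with its 2 heavy atoms and 1 hydrogen-bond acceptor, can be lost here with no change beyond the scatter. No measurement at hand bears on why these two compounds read alike.

Going by these compounds, whether a chlorine, an amine or a carboxylic acid at this position would move the number beyond the scatter stays open, as does whether the same change reads alike with a methyl on the selenium. Compound 3 differs from the others in more than one place, and the compounds shown do not tell which of those differences goes with its 14400 nM in this assay.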